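The source may report more compounds than this note shows. Statements on the series, on what has been measured and on what is new or still open speak of the compounds shown alone.

Of the compounds shown here, three built on one shared core have been tested in a functional assay on Hep 3B2 cells (Homo sapiens) for antiproliferative activity, read by MTT assay, with a stated time of 24 h, tested at 100 ug/mL; on this read-out higher numbers stand for a stronger effect at the one concentration tested and lower numbers for a weaker effect. Compound 1, `COc1ccc2nc(C(=O)Nc3ccc(-c4ccccc4)cc3)c(C)c(O)c2c1`, gives 79.3%. Compound 2, `Cc1c(C(=O)Nc2ccc(-c3ccccc3)cc2)nc2ccccc2c1O`, gives 84.3%. Compound 3, `COc1ccc2nc(C(=O)Nc3ccc(-c4ccccc4)cc3)c(C)c(C(=O)O)c2c1`, gives 72.5%. On these numbers compound 3 stays inside the usual scatter of compound 1, as the step of a number 6.8 percentage points lower from compound 1 to compound 3 (within the scatter) shows, whereas the number of compound 2 lies above that of compound 3 by more than the scatter.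

Compound 4, `Cc1c(C(=O)Nc2ccc(-c3ccccc3)cc2)nc2ccccc2c1C(=O)O`, has not yet been measured. It differs from compound 3 in one place: hydrogen in place of methoxy on an aromatic carbon. Among the compounds with values here, one measured step bears directly on this. The same exchange was made on the hydroxy-bearing pair, where the step of a number 5 percentage points higher from compound 1 to compound 2 (within the scatter) did not leave the scatter. The carboxy-bearing pair is therefore expected to behave alike. The step of a number 4.5 percentage points higher from compound 3 to compound 4 (within the scatter) is expected to stay within the scatter. Compound 4 is estimated to give about 77%, with a likely range from 66% to 88%.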

Compound 4, a percentage reported as inhibition, at one concentration (the size of the read-out at that concentration, not a potency): 44.4%
Estimate against measurement, compound 4: 32.6 percentage points above, and the stated range ends above it.
By their numbers in this assay, from the lowest: compound 4; then compounds 3, 1 and 2 (each within the scatter of the next, the first and the last beyond it).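

In this assay, the exchange of methoxy for hydrogen gives a number 28.1 percentage points lower from compound 3 to compound 4 (beyond the scatter), so the outcome of this exchange on the aromatic carbon depends on which group the core carries at the other varied place: the same change on two cores in this assay, a number 5 percentage points higher (within the scatter) from compound 1 to compound 2 and a number 28.1 percentage points lower (beyond the scatter) from compound 3 to compound 4, 33.1 percentage points apart, beyond the scatter of two such steps. Read the other way, carboxy in place of hydroxy gives a number 39.9 percentage points lower from compound 2 to compound 4 (beyond the scatter) on the core without methoxy, and this change too depends on its partner: the same change on two cores in this assay, a number 6.8 percentage points lower (within the scatter) from compound 1 to compound 3 and a number 39.9 percentage points lower (beyond the scatter) from compound 2 to compound 4, 33.1 percentage points apart, beyond the scatter of two such steps. The two changes therefore do not simply add up across these four compounds, and the methoxy group makes a difference beyond the scatter only on the carboxy-bearing pair.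

Going by these compounds, it remains open whether another group at that place, such as a chlorine atom or an amine, would act like methoxy on the carboxy-bearing core. A methyl ester in place of the carboxy group could show whether the dependence on methoxy persists.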